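The source may hold more compounds than are shown below. What is called first, only, known or untested is meant among the compounds shown, and "the series" means these compounds.

Measured so far in a functional assay on MDA-MB-231 cells (Homo sapiens) for antiproliferative activity, read by CCK-8 assay, with a stated time of 48 h; on this read-out lower numbers stand for stronger inhibition and higher numbers for weaker inhibition:
Compound 1 `CNC(=O)/C=C/CN1CC(Oc2ccc(Oc3c(-c4ccc(F)cc4)sc4cc(O)ccc34)cc2)C1`: > 50000 nM
Compound 2 `CNC(=O)/C=C/CNCCOc1ccc(Oc2c(-c3ccc(F)cc3)sc3cc(O)ccc23)cc1`: > 50000 nM
Compound 3 `O=C(/C=C/CN1CC(Oc2ccc(Oc3c(-c4ccc(F)cc4)sc4cc(O)ccc34)cc2)C1)N1CCCC1`: > 50000 nM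

All three entries are limits of the assay, not numbers. Compound 3 sits at the limit of > 50000 nM in this assay, at which 3 of the 3 values shown sit.

Compound 4 `CN(C)C(=O)/C=C/CN1CC(Oc2ccc(Oc3c(-c4ccc(F)cc4)sc4cc(O)ccc34)cc2)C1` differs from compound 3 in one place: dimethylamino in place of pyrrolidin-1-yl on a carbonyl carbon. This puts dimethylamino in place of pyrrolidin-1-yl on a carbonyl carbon.

The closest measured change, on that same carbonyl carbon, is a step that the two limits leave unreadable from compound 1 to compound 3. The other is a step that the two limits leave unreadable from compound 1 to compound 2. Neither has a readable size, so neither suggests a direction.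

Starting from the limit of compound 3, > 50000 nM, no step beyond the scatter is expected in this assay, and another limit is the likeliest result.

For compound 4 the estimated value is 60000 nM, with an expected range of 25000 nM to 100000 nM.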

Compound 4, half-maximal inhibitory concentration: > 50000 nM
Compound 4 gave a limit, no number; the forecaster's own chance of this, stated with the estimate: 90%; the middle value is on the limit's open side.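

Compound 4 also gives only a limit, so its steps from compound 1, compound 2 and compound 3 cannot be read. Whether any change to these compounds would give a readable number stays open: the limit of > 50000 nM in this assay, at which 4 of the 4 values shown sit.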